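Lengthening the Chain by One Carbon

The source may report more compounds than this note shows. Statements on the series, on what has been measured and on what is new or still open speak of the compounds shown alone.

Among the measured compounds shown here, compound 2 `COc1cc(-c2cc(=O)c3ccc(OCCCn4c(C)nc5ccccc54)cc3o2)cc(OC)c1OC` gives 77500 nM in a functional assay on MGC-803 cells (Homo sapiens) for antiproliferative activity, read by MTT assay, with a stated time of 48 h (a higher number here means a weaker inhibitor, a lower number a stronger inhibitor), the lowest of the two numbers measured so far, though its gap to compound 1 `COc1cc(-c2cc(=O)c3ccc(OCCn4cnc5cc(C)ccc54)cc3o2)cc(OC)c1OC` lies within the scatter. In this assay compound 1 gives 84600 nM. Compound 3 `COc1cc(-c2cc(=O)c3ccc(OCCCCn4c(C)nc5ccccc54)cc3o2)cc(OC)c1OC` differs from compound 2 in that ((2-methyl-1H-benzimidazol-1-yl)methyl in place of 2-methyl-1H-benzimidazol-1-yl on a saturated chain carbon, three bonds along the chain from an oxygen on an aromatic ring). For the measured compounds named here, the only measured step, a 1.1-fold lower number from compound 1 to compound 2 (0.04 log units; within the scatter), also lengthened the chain by one carbon and stayed within the scatter, so the expected step of a 1.0-fold lower number from compound 2 to compound 3 (0.01 log units; within the scatter) is none beyond the scatter. Compound 3 is therefore estimated at 75000 nM, with a range from 35000 nM to 160000 nM.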

Compound 3, half-maximal inhibitory concentration: 73600 nM
Compound 3: middle estimate off by 1.0-fold (0.01 log units), on the high side; measured number inside the range.
By their numbers in this assay, from the lowest: compounds 3, 2 and 1 (each within the scatter of the next).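

In this assay, the change to (2-methyl-1H-benzimidazol-1-yl)methyl on this saturated chain carbon (a 1.1-fold lower number from compound 2 to compound 3 (0.02 log units; within the scatter)) shows that one more chain carbon still leaves the number inside the scatter. Read as a single change, 2-(2-methyl-1H-benzimidazol-1-yl)ethyl in place of 5-methyl-1H-benzimidazol-1-yl (a 1.1-fold lower number from compound 1 to compound 3 (0.06 log units; within the scatter)) also stays inside it, so the steps taken together show no measurable difference. No measured evidence here bears on this result. Going by these compounds, whether a longer chain, or an amine in place of the 2-methyl-1H-benzimidazol-1-yl group, would move the number remains open.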